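The compounds below may be only part of what the source reports. "The series", "measured", "known", "first", "only" and "open" are said of these compounds alone.

Working notes on the series. In a toxicity assay on HEK-293T cells (Homo sapiens) for cytotoxicity, read by MTT assay, with a stated time of 48 h (on this read-out higher numbers stand for weaker inhibition and lower numbers for stronger inhibition), compound 1 `C=C1[C@H](OC(C)=O)[C@@H](OC(C)=O)[C@@H](O)C(C)(C)/C=C/[C@H](C)[C@H](OC(=O)c2ccccc2)[C@@]2(O)C[C@@](C)(O)[C@H](OC(C)=O)[C@@H]2[C@H]1OCC(C)C` reads > 100000 nM, which is a limit of the assay and not a number. Compound 2 `C=C1[C@H](OC(C)=O)[C@@H](OC(C)=O)[C@@H](OC(C)=O)C(C)(C)/C=C/[C@H](C)[C@H](OC(=O)c2ccccc2)[C@@]2(O)C[C@@](C)(O)[C@H](OC(C)=O)[C@@H]2[C@H]1OCC(C)C` gives 39300 nM and compound 3 `C=C1[C@H](OC(C)=O)[C@@H](OC(=O)C(C)(C)C)[C@@H](OC(C)=O)C(C)(C)/C=C/[C@H](C)[C@H](OC(=O)c2ccccc2)[C@@]2(O)C[C@@](C)(O)[C@H](OC(C)=O)[C@@H]2[C@H]1OCC(C)C` gives 52100 nM. Among the compounds with values here, these two numbers lie within the scatter of each other, and they are the only true numbers so far.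

Compound 4 `C=C1[C@H](OC(C)=O)[C@@H](OC(C)=O)[C@@H](OC(C)=O)C(C)(C)/C=C/[C@H](C)[C@H](OC(=O)c2ccccc2)[C@@]2(O)C[C@@](C)(OC(=O)C(C)(C)C)[C@H](OC(C)=O)[C@@H]2[C@H]1OCC(C)C` differs from compound 2 by (tert-butyl)carbonyl in place of hydrogen on an oxygen on a saturated carbon, with (tert-butyl)carbonyl in place of hydrogen on an oxygen on a saturated carbon. Within the data shown here, two measured steps bear on this, though neither falls on this oxygen. Acetyl in place of hydrogen on an oxygen on a saturated carbon gave an at least 2.5-fold lower number from compound 1 to compound 2 (0.40 log units; beyond the scatter). Tert-butyl in place of methyl on a carbonyl carbon gave a 1.3-fold higher number from compound 2 to compound 3 (0.12 log units; within the scatter), so the larger group changed little there. A small move to a lower number is therefore expected, and it may not clear the scatter: the estimated step is a 1.3-fold lower number from compound 2 to compound 4 (0.12 log units; within the scatter). In this assay the estimate for compound 4 is 30000 nM, with an expected range of 11000 nM to 85000 nM.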

Compound 4, half-maximal inhibitory concentration: 56300 nM
The estimate for compound 4 lay 1.9-fold (0.27 log units) below the measured number, and the stated range covers the measured number.
By their numbers in this assay, from the lowest: compounds 2, 3 and 4 (each within the scatter of the next). At a limit, above all of these: compound 1.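

In this assay, hydroxy to ((tert-butyl)carbonyl)oxy on this oxygen gives a 1.4-fold higher number from compound 2 to compound 4 (0.16 log units; within the scatter), so this position carries the ester with a number that stays within the scatter of the free hydroxy compound. Putting an acyl group on a hydroxy therefore does not repeat here what acetyl did on the other oxygen, where the change gave an at least 2.5-fold lower number from compound 1 to compound 2 (0.40 log units; beyond the scatter), although the two groups also differ from each other. That earlier step stays open-ended, since compound 1 is a limit of the assay: the limit of > 100000 nM in this assay, at which 1 of the 4 values shown sits.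

As far as these compounds go, whether an amine or a carboxylic acid carried on this oxygen would take the number beyond the scatter remains open. From the compounds shown here alone, all the values also come from a single cell assay, so the effect of this change on any other read-out is unknown.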